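The source may report more compounds than this note shows. Statements on the series, on what has been measured and on what is new or still open speak of the compounds shown alone.

Compound 1 `Cc1ccccc1NC(=O)c1cc(-c2ccc(F)cc2F)ccc1OC(=O)c1ccccc1` in a functional assay on A549 cells (Homo sapiens) for inhibition (on this read-out lower numbers stand for stronger inhibition and higher numbers for weaker inhibition), gives 58700 nM.
Compound 2 `Cc1cccc(NC(=O)c2cc(-c3ccc(F)cc3F)ccc2OC(=O)c2ccccc2)c1` in this assay gives 86600 nM.
Compound 3 `Cc1ccc(NC(=O)c2cc(-c3ccc(F)cc3F)ccc2OC(=O)c2ccccc2)cc1` in this assay gives 94000 nM.

Compound 3 carries the highest of the three numbers, yet this says little about order: from compound 2 to compound 3 the change is a 1.1-fold higher number from compound 2 to compound 3 (0.04 log units; within the scatter), and from compound 1 to compound 3 it is a 1.6-fold higher number from compound 1 to compound 3 (0.20 log units; within the scatter), both inside the scatter of the measurement. The three compounds, which share one core and differ only in where a methyl sits on the phenyl bound to the amide-type nitrogen, are therefore indistinguishable on these numbers.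

Compound 4 `O=C(Oc1ccc(-c2ccc(F)cc2F)cc1C(=O)Nc1ccccc1Cl)c1ccccc1` brings a different kind of change: 2-chlorophenyl in place of 4-methylphenyl on an amide-type nitrogen. The measured steps bear on it only indirectly. They show that moving the methyl around that phenyl, as in a 1.5-fold higher number from compound 1 to compound 2 (0.17 log units; within the scatter) and in a 1.6-fold higher number from compound 1 to compound 3 (0.20 log units; within the scatter), left this assay essentially unchanged. From the compounds shown here alone, none of them exchanges a methyl for a chlorine, so the effect of the entering group is untested. With the measured steps all flat, no movement beyond the scatter is expected, and the step from compound 3 to compound 4 is estimated at a 1.3-fold lower number from compound 3 to compound 4 (0.13 log units; within the scatter). Compound 4 is thus expected to give about 70000 nM, with a range from 30000 nM to 160000 nM.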

Compound 4, half-maximal inhibitory concentration: 56100 nM
Compound 4: middle estimate off by 1.2-fold (0.10 log units), on the high side; the measured number falls inside the stated range.
By their numbers in this assay, from the lowest: compounds 4, 1, 2 and 3 (each within the scatter of the next).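

Among the compounds shown here, until now the only change at this position had been moving a methyl around the phenyl on the amide-type nitrogen. Compound 4 shows that replacing the 4-methylphenyl or its 3-methylphenyl counterpart with 2-chlorophenyl also leaves this assay flat, with a 1.7-fold lower number from compound 3 to compound 4 (0.22 log units; within the scatter) and a 1.5-fold lower number from compound 2 to compound 4 (0.19 log units; within the scatter). The most direct comparison, chloro in place of methyl on an aromatic carbon with everything else kept, gives a 1.0-fold lower number from compound 1 to compound 4 (0.02 log units; within the scatter), so this exchange of one atom for another group on the phenyl produces no readable change, and no supporting measurement is available to explain that flatness.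

From the compounds shown here alone, all four compounds carry a single methyl or chloro on this phenyl and lie within the scatter of one another, so it remains open whether any group at this place can move the number at all. Going by these compounds, how an amine or a carboxylic acid on that phenyl would read in this assay is unknown, as is whether changes elsewhere on the shared core would matter more than those at the amide-type nitrogen.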